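From benzyl to 4-methoxyphenyl on selenium

This account rests on a few compounds, and the source may have more. Where it says the series, first, only, none or still open, it means among the compounds named here.

Within the data shown here, in a functional assay on Jurkat cells (Homo sapiens) for cytotoxicity, read by MTT assay, with a stated time of 24 h (on this read-out higher numbers stand for an effect only at larger amounts of compound and lower numbers for an effect already at smaller amounts), compound 1 (`CCOC(=O)c1cc([Se]Cc2ccccc2)c2cc(OC)ccc2n1`) gives 20800 nM and compound 2 (`CCOC(=O)c1cc([Te]c2ccccc2)c2cc(OC)ccc2n1`) gives 77400 nM, so compound 1 holds the lower of the only two numbers available. Compound 3 (`CCOC(=O)c1cc([Se]c2ccc(OC)cc2)c2cc(OC)ccc2n1`) keeps the selenium and the core of compound 1 and differs in one place (4-methoxyphenyl in place of benzyl on a selenium): 4-methoxyphenyl in place of benzyl on a selenium.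

Among the measured compounds shown here, only one measured step bears on this change (a 3.7-fold higher number from compound 1 to compound 2 (0.57 log units; beyond the scatter)), and it is modest. That step replaces the selenium as well as the group it carries, so it gives only partial guidance. For the measured compounds named here, no measured compound carries 4-methoxyphenyl, and no measured step isolates the loss of benzyl. A shift in the same direction is therefore expected, smaller than the measured step, with wide uncertainty.

In this assay the expected change is an estimated (a 1.7-fold higher number from compound 1 to compound 3 (0.23 log units; within the scatter)) toward a higher number. For compound 3 the estimated value is 35000 nM with an expected range from 11000 nM to 100000 nM as the working bounds.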

Compound 3, half-maximal effective concentration: 82500 nM
The estimate for compound 3 lay 2.4-fold (0.37 log units) below the measured number, and the stated range covers the measured number.
By their numbers in this assay, from the lowest: compound 1; then compounds 2 and 3 (each within the scatter of the next).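

Holding the selenium fixed, the step in this assay isolates the group on selenium for the first time: a 4.0-fold higher number from compound 1 to compound 3 (0.60 log units; beyond the scatter), a modest step and the first in this series with a single change at this position. The earlier step, a 3.7-fold higher number from compound 1 to compound 2 (0.57 log units; beyond the scatter), replaced the selenium and its group together, whereas this result shows that a change of group alone, with the element kept, is enough to move the number beyond the scatter. No measurement of any property accompanies these numbers, so the data offer no explanation for the shift.

The step cannot be divided between the loss of benzyl and the entry of 4-methoxyphenyl, and the share of the tellurium in the earlier step also remains unresolved, as neither plain phenyl on selenium nor 4-methoxyphenyl on tellurium is among the compounds shown. Also open, from the compounds shown here alone, is what a quite different group on the selenium, such as an aminoethyl or a longer alkyl chain, would give in this assay.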